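A few compounds are considered here, and "the series" means these few. Any claim that something is new, unique, unknown or untested is made for them only; others in the source may bear on it.

The compounds share one core and differ only in the aryl group on the carbon with a double bond to nitrogen. In a functional assay on PC-3 cells (Homo sapiens) for antiproliferative activity, read by MTT assay (on this read-out higher numbers stand for weaker inhibition and lower numbers for stronger inhibition), compound 3 `COc1cccc(/C=N/Nc2ncc3c(n2)n(C2CCCC2)c(=O)c(=O)n3C)c1` gives 20700 nM, the highest of the two plain numbers shown; the nearest is compound 2 `Cn1c(=O)c(=O)n(C2CCCC2)c2nc(N/N=C/c3ccc(Cl)cc3)ncc21`, which gives 8420 nM. Compound 1 `Cn1c(=O)c(=O)n(C2CCCC2)c2nc(N/N=C/c3ccc(O)cc3)ncc21` returns only a limit, > 100000 nM. The steps of an at least 11-fold lower number from compound 1 to compound 2 (1.07 log units; beyond the scatter) and an at least 4.8-fold lower number from compound 1 to compound 3 (0.68 log units; beyond the scatter) both start from that limit (the limit of > 100000 nM in this assay, at which 1 of the 3 values shown sits), while the step of a 2.5-fold higher number from compound 2 to compound 3 (0.39 log units; beyond the scatter) compares two actual numbers. Compound 4 `Cn1c(=O)c(=O)n(C2CCCC2)c2nc(N/N=C/c3cccc(Cl)c3Cl)ncc21` has not yet been measured; it differs from compound 3 by 2,3-dichlorophenyl in place of 3-methoxyphenyl on a carbon with a double bond to nitrogen. The measured step that bears most directly on this change is a 2.5-fold higher number from compound 2 to compound 3 (0.39 log units; beyond the scatter), in which a chlorophenyl gave the lower number than a methoxyphenyl, and an at least 11-fold lower number from compound 1 to compound 2 (1.07 log units; beyond the scatter) points the same way for a chloro substituent. For compound 4 a modest downward step in this assay is therefore expected, a 3.5-fold lower number from compound 3 to compound 4 (0.54 log units; beyond the scatter). Compound 4 is estimated to give about 6000 nM, with a range from 2000 nM to 20000 nM.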

Compound 4, half-maximal inhibitory concentration: 17200 nM
Compound 4: middle estimate off by 2.9-fold (0.46 log units), on the low side; measured number inside the range.
By their numbers in this assay, from the lowest: compound 2; then compounds 4 and 3 (each within the scatter of the next). At a limit, above all of these: compound 1.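

Adding chlorine to the aryl group does not by itself lower the number: in this assay the change is a 1.2-fold lower number from compound 3 to compound 4 (0.08 log units; within the scatter), so 2,3-dichlorophenyl and 3-methoxyphenyl cannot be told apart at this position. The lower number seen with 4-chlorophenyl therefore does not extend to every chlorinated aryl group, as the step of a 2.0-fold higher number from compound 2 to compound 4 (0.31 log units; beyond the scatter) shows. The step of an at least 5.8-fold lower number from compound 1 to compound 4 (0.76 log units; beyond the scatter) gives only a bound, and it starts from a limit for compound 1: the limit of > 100000 nM in this assay, at which 1 of the 4 values shown sits.

The compounds shown do not separate the effect of how many chlorines the aryl group carries from that of where they sit, and a 2-chlorophenyl or 3-chlorophenyl group would bear on this. As far as these compounds go, how an aryl group carrying an amine or a carboxylic acid would read in this assay also remains open.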